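This account rests on a few compounds, and the source may have more. Where it says the series, first, only, none or still open, it means among the compounds named here.

Working notes on the series, read in a functional assay on the whole organism with Mus musculus as the target; on this read-out lower numbers stand for an effect already at smaller amounts and higher numbers for an effect only at larger amounts of compound. Compound 1 `COc1cc2c(cc1OC)C(c1ccccc1)=NNC(=O)C2` gives 10 mg/kg and compound 2 `COc1cc2c(cc1OC)C(c1cccc(N)c1)=NNC(=O)C2` gives 6 mg/kg. These two numbers lie within the scatter of each other, so compound 2 stands level with compound 1 and no order can be drawn between them.

Compound 3 `COc1cc2c(cc1OC)C(c1ccc(N)cc1)=NNC(=O)C2` has not yet been measured. The change to it is 4-aminophenyl in place of 3-aminophenyl on a carbon with a double bond to nitrogen. In short, 4-aminophenyl stands in place of 3-aminophenyl on a carbon with a double bond to nitrogen.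

Going by the values given here, no measured pair compares these two groups directly. Among the compounds with values here, only one measured step bears on the change: a 1.7-fold lower number from compound 1 to compound 2 (0.22 log units; within the scatter), where amino replaces hydrogen on an aromatic carbon. That step stays within the scatter, and with a single step as evidence the read-across is weak. No step beyond the scatter is therefore expected in this assay, and no direction can be assigned with confidence. The expected step is a 1.2-fold lower number from compound 2 to compound 3 (0.08 log units; within the scatter), which would remain within the scatter. For compound 3 the estimated value is 5 mg/kg, with an expected range from 2.5 mg/kg to 12 mg/kg.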

Compound 3, dose for half-maximal effect: 4.66 mg/kg
The estimate for compound 3 lay 1.1-fold (0.03 log units) above the measured number; the measured number falls inside the stated range.
By their numbers in this assay, from the lowest: compounds 3, 2 and 1 (each within the scatter of the next, the first and the last beyond it).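

In this assay, exchanging 3-aminophenyl for 4-aminophenyl on a carbon with a double bond to nitrogen gives a 1.3-fold lower number from compound 2 to compound 3 (0.11 log units; within the scatter) and so leaves compound 2 and compound 3 level: the two placings of the amino group cannot be told apart at this position. Amino in place of hydrogen on an aromatic carbon now gives a 2.1-fold lower number from compound 1 to compound 3 (0.33 log units; beyond the scatter) as the first step in the series beyond the scatter, though only a modest one, whereas the same kind of change in the other placing gave a 1.7-fold lower number from compound 1 to compound 2 (0.22 log units; within the scatter) and stayed within it. The series therefore has one measured gain over the unsubstituted phenyl of compound 1, and no data here explain it.

The compounds shown leave open whether 2-aminophenyl at the same carbon would stand level with 3-aminophenyl and 4-aminophenyl, and whether the amino group itself matters or a hydroxyl, a dimethylamino group or an acetamide in its place would serve as well. They also leave open whether the modest step from the amino group would hold with an ethoxy group in place of either methoxy group on the shared core.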